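The source may report more compounds than this note shows. Statements on the series, on what has been measured and on what is new or still open speak of the compounds shown alone.

Measured so far: compound 1, `N#Cc1cc(Cl)cc(Oc2c(Cl)ccc3c2nnn3Cc2n[nH]c3nc(N)ccc23)c1`, in an in vivo ADME assay on the whole organism (strain Sprague-Dawley) for pharmacokinetics, with Rattus norvegicus as the target (a higher number here means that a larger share of the oral dose reaches the circulation, a lower number that a smaller share of the oral dose reaches the circulation), gives < 1%; compound 2, `N#Cc1cc(Cl)cc(Oc2c(Cl)ccc3c2cnn3Cc2n[nH]c3ncccc23)c1`, gives 76% in this assay.

The value of compound 1 is a limit of this assay, not a number. Compound 2 stands at the only number shown, with the limit of < 1% in this assay, at which 1 of the 2 values shown sits, beside it. Compound 3, `N#Cc1cc(Cl)cc(Oc2c(Cl)ccc3c2cnn3Cc2n[nH]c3nc(N)ccc23)c1`, differs from compound 2 by amino in place of hydrogen on an aromatic carbon. For the measured compounds named here, no step between measured compounds is available here, so the expected step is drawn only from what the two values show. A drop beyond the scatter is expected from compound 2 to compound 3, a number 46 percentage points lower from compound 2 to compound 3 (beyond the scatter), because compound 1 gives < 1%. Compound 3 is expected to give 30%, between 3% and 65%.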

Compound 3, oral bioavailability in the Rattus norvegicus assay: 39%
For compound 3 the middle estimate is 9 percentage points below the measured one, within the range that was stated.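

Compound 1 and compound 2 differ in more than one place, whereas this pair isolates the amino group on an aromatic carbon next to the ring nitrogen, and in the Rattus norvegicus assay the change reads a number 37 percentage points lower from compound 2 to compound 3 (beyond the scatter). In a physicochemical assay for solubility, at pH 2 (on this read-out higher numbers stand for higher solubility and lower numbers for lower solubility), compound 2 gives < 0.1 ug/mL, which is a limit of the assay. In the physicochemical assay compound 3 gives 40 ug/mL. In the physicochemical assay the change reads an at least 400-fold higher number from compound 2 to compound 3 (2.60 log units; beyond the scatter). The two read-outs thus move in opposite ways.

From the compounds shown here alone, whether a methylamino or a hydroxyl group on the same carbon would give the same split between the two read-outs remains open.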